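Amino-substituted styryl sulfones in K562 cytotoxicity

This account rests on a few compounds, and the source may have more. Where it says the series, first, only, none or still open, it means among the compounds named here.

Measured compounds:
compound 1 `COc1ccc(CS(=O)(=O)/C=C/c2c(OC)cc(OC)cc2OC)c(N)c1`, 25 nM
compound 2 `COC(=O)C(F)(F)Nc1cc(CS(=O)(=O)/C=C/c2c(OC)cc(OC)cc2OC)ccc1OC`, 250 nM

In a functional assay on K562 cells (Homo sapiens) for cytotoxicity, read by trypan blue exclusion, with a stated time of 96 h (on this read-out higher numbers stand for weaker inhibition and lower numbers for stronger inhibition), compound 2 gives 250 nM, the highest of the two numbers at hand; compound 1 gives 25 nM, a lower number beyond the scatter. Among the compounds with values here, no single-change step joins these two. Compound 3 `COc1cc(OC)c(/C=C/S(=O)(=O)Cc2ccc(OC)c(NC(C(=O)O)c3ccc(F)cc3)c2)c(OC)c1` is not yet measured. Its change from compound 2 reads (carboxy(4-fluorophenyl)methyl in place of difluoro(methoxycarbonyl)methyl on a nitrogen on an aromatic ring). Nothing measured links this change to a known step, so the expected step of a 1.7-fold lower number from compound 2 to compound 3 (0.22 log units; within the scatter) is modest, toward a lower number, and may not exceed the scatter. Compound 3 is estimated at 150 nM, within 40 nM to 600 nM.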

Compound 3, half-maximal inhibitory concentration: 80 nM
For compound 3 the middle estimate is 1.9-fold (0.27 log units) above the measured one; low and high end bracket the measured number.
By their numbers in this assay, from the lowest: compound 1; then compound 3; then compound 2.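

In this assay, within the data shown here, carboxy(4-fluorophenyl)methyl in place of difluoro(methoxycarbonyl)methyl on a nitrogen on an aromatic ring gives a 3.1-fold lower number from compound 2 to compound 3 (0.49 log units; beyond the scatter), the only single-change step at hand. The substituent on this nitrogen can therefore grow by a six-membered aromatic ring without a loss of activity, although the change alters several features at once. Nothing measured accounts for the step.

The compounds shown leave open whether the carboxylic acid or the 4-fluorophenyl ring carries the step. A methyl ester or a phenyl ring without fluorine in the same group would separate the two.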